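Adding a nitro group to compound 3

A few compounds are considered here, and "the series" means these few. Any claim that something is new, unique, unknown or untested is made for them only; others in the source may bear on it.

Measured so far in a functional assay on AGS cells (Homo sapiens) for inhibition, read by reporter gene assay; a lower number here means a stronger inhibitor, a higher number a weaker inhibitor:
- Compound 1 `O=C(COc1ccccc1)Nc1cccc(C(=O)O)c1`: > 30000 nM
- Compound 2 `Cc1ccc(OCC(=O)Nc2cccc(C(=O)O)c2)cc1`: > 30000 nM
- Compound 3 `NC(=O)c1cccc(NC(=O)COc2ccccc2)c1`: > 30000 nM

Each of these entries is a limit of the assay and not a number, and the same ceiling applies throughout: the limit of > 30000 nM in this assay, at which 3 of the 3 values shown sit. Compound 3 therefore has no exact value to build on, only its limit of > 30000 nM.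

Compound 4 `NC(=O)c1cccc(NC(=O)COc2ccc([N+](=O)[O-])cc2)c1` has not yet been measured. It differs from compound 3 by nitro in place of hydrogen on an aromatic carbon.

Two measured changes bear on this. The closer one, methyl in place of hydrogen on an aromatic carbon, is a step that the two limits leave unreadable from compound 1 to compound 2. The other, amino in place of hydroxy on a carbonyl carbon, is a step that the two limits leave unreadable from compound 1 to compound 3. Neither provides a size to carry over, so no firm direction can be expected in this assay, and another limit is the likeliest result.

The expected change is an at least 1.2-fold lower number from compound 3 to compound 4 (0.07 log units; that floor lies within the scatter). For compound 4 the estimated value is 25000 nM, with an estimated range of 6000 nM to 60000 nM.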

Compound 4, half-maximal inhibitory concentration: > 30000 nM
Compound 4 ended at the assay's limit; the forecaster's own chance of this, stated with the estimate: 60%; middle value at least 1.2-fold (0.07 log units) from the limit.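

Among the compounds shown here, compound 3 and compound 4 both stop at a limit of this assay and not at a number, so no step between them can be read: the limit of > 30000 nM in this assay, at which 4 of the 4 values shown sit. The compounds shown leave open whether any change to this series gives a measurable value in this assay.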